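The source may hold more compounds than are shown below. What is called first, only, known or untested is meant among the compounds shown, and "the series" means these compounds.

Working notes on the series. Compound 1 `O=[N+]([O-])c1cccc(-c2ccc(O[C@H]3O[C@H](CO)[C@@H](O)[C@H](O)[C@@H]3O)c(Cl)c2)c1` and compound 2 `N#Cc1cccc(-c2ccc(O[C@H]3O[C@H](CO)[C@@H](O)[C@H](O)[C@@H]3O)c(Cl)c2)c1` share a core and differ only in the group on the distal aromatic ring. In a physicochemical assay for lipophilicity, read by LC-MS, measured as octanol-water partition, with a stated time of 2 h, at pH 7.4, tested at 1 uM (on this read-out higher numbers stand for higher lipophilicity and lower numbers for lower lipophilicity), compound 1 gives 2.4 and compound 2 gives 2.1. Going by the values given here, the one measured step, a number 0.30 log units lower from compound 1 to compound 2 (within the scatter), is within the scatter, so the two numbers cannot be ordered. Compound 2 stands at the lowest of the two numbers shown, with compound 1 nearest.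

Compound 3 `OC[C@H]1O[C@H](Oc2ccc(-c3ccc(Cl)cc3)cc2Cl)[C@@H](O)[C@@H](O)[C@@H]1O` is not yet measured in this assay. It differs from compound 2 in one place: 4-chlorophenyl in place of 3-cyanophenyl on an aromatic carbon. Among the compounds with values here, the only measured step bears on it indirectly, since it also changes the group on this ring, and it was within the scatter; no measured step involves a chloro group entering or a cyano group leaving, so no direct precedent exists. The step from compound 2 to compound 3 is expected to be an increase in this assay, a number 1.00 log units higher from compound 2 to compound 3 (beyond the scatter). Compound 3 is estimated at 3.1, with a range from 2.6 to 3.6.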

Compound 3, distribution coefficient: 3.3
Compound 3: middle estimate off by 0.20 log units, on the low side; the range from low to high includes it.
By their numbers in this assay, from the lowest: compounds 2 and 1 (each within the scatter of the next); then compound 3.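

Replacing the ring group gives a number 1.20 log units higher from compound 2 to compound 3 (beyond the scatter) and a number 0.90 log units higher from compound 1 to compound 3 (beyond the scatter) in this assay at this place, on an aromatic carbon meta to a chloro group and para to a large group. Going by these compounds alone, the earlier pair showed only a step within the scatter, so these are the first steps to show that the read-out can respond to a change at this place, and the result holds from both compound 1 and compound 2. The 4-chlorophenyl group differs from both 3-cyanophenyl and 3-nitrophenyl in its substituent and in where that substituent stands on the ring, so these two differences can be read only together, and nothing measured here explains the step.

On these data alone, it remains open how much of the step belongs to the chloro group itself and how much to the removal of the earlier substituent, which a plain phenyl group at this place would help to separate. As far as these compounds go, it is also open how groups of another kind would read here, such as an amine or a carboxylic acid on the ring, or a longer chain in place of it.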